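A Flat Step and a New Chain Ending

A few compounds are considered here, and "the series" means these few. Any claim that something is new, unique, unknown or untested is made for them only; others in the source may bear on it.

Values in a functional assay on HepG2 cells (Homo sapiens) for inhibition, read by MTT assay, with a stated time of 3 days; on this read-out lower numbers stand for stronger inhibition and higher numbers for weaker inhibition:
Compound 1 `COc1cc(-c2nc3ccccc3s2)ccc1OCC(=O)NNC(=O)CCl`: 2890 nM
Compound 2 `CCOC(=O)[C@H](CS)N(CC(=O)NNC(=O)COc1ccc(-c2nc3ccccc3s2)cc1OC)C(C)=O`: 3010 nM

Compound 2 stands level with compound 1. The two values lie within the scatter of each other. Compound 3 `CCOC(=O)[C@H](CS(=O)(=O)O)NCC(=O)NNC(=O)COc1ccc(-c2nc3ccccc3s2)cc1OC` has not yet been measured. It carries (1-(ethoxycarbonyl)-2-sulfoethyl)amino in place of acetyl(1-(ethoxycarbonyl)-2-sulfanylethyl)amino on a saturated chain carbon bound to a carbonyl carbon. Among the compounds with values here, one measured step bears on this place, a 1.0-fold higher number from compound 1 to compound 2 (0.02 log units; within the scatter), and it brought acetyl(1-(ethoxycarbonyl)-2-sulfanylethyl)amino in place of chloro. Within the data shown here, no measured compound carries the entering group, so this evidence is thin. In this assay, no step beyond the scatter is therefore expected. The expected change is a 1.2-fold higher number from compound 2 to compound 3 (0.07 log units; within the scatter). Compound 3 is estimated at 3500 nM, with an expected range of 1200 nM to 12000 nM.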

Compound 3, half-maximal inhibitory concentration: 3360 nM
Beside the measured number, compound 3's estimate is 1.0-fold (0.02 log units) above it; low and high end bracket the measured number.
By their numbers in this assay, from the lowest: compounds 1, 2 and 3 (each within the scatter of the next).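

Replacing acetyl(1-(ethoxycarbonyl)-2-sulfanylethyl)amino with (1-(ethoxycarbonyl)-2-sulfoethyl)amino on a saturated chain carbon bound to a carbonyl carbon gives a 1.1-fold higher number from compound 2 to compound 3 (0.05 log units; within the scatter) in this assay. The same group in place of chloro gives a 1.2-fold higher number from compound 1 to compound 3 (0.07 log units; within the scatter), so this position has now taken three different groups with all values within the scatter of each other, and the sulfo chain ending, unlike the earlier sulfanyl one, comes without the acetyl on the nitrogen. Nothing accompanying these values explains this flat result.

On these data alone, it remains open whether a carboxylic acid in place of the sulfo group, or a simple amine in place of the whole chain, would also stay level. All three compounds share one core, so it is also unknown whether a change in that core would shift the number.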